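The source may report more compounds than this note shows. Statements on the series, on what has been measured and on what is new or still open speak of the compounds shown alone.

Measured compounds:
Compound 1 `CCc1c(Cc2c(Cl)cccc2Cl)nc(SCC(=O)c2ccc(F)cc2)[nH]c1=O` — > 55000 nM
Compound 2 `CCc1c(Cc2c(Cl)cccc2Cl)nc(SCC(=O)c2ccc(OC)cc2)[nH]c1=O` — > 54000 nM
Compound 3 `Cc1c(Cc2c(F)cccc2F)nc(SCC(=O)c2ccc(F)cc2)[nH]c1=O` — > 62000 nM

In an ADME assay on MT4 cells (Homo sapiens) for cytotoxicity, read by MTT assay (on this read-out higher numbers stand for lower toxicity in this test and lower numbers for higher toxicity in this test), compound 1 gives > 55000 nM, which is a limit of the assay rather than a number. In this assay compound 2 gives > 54000 nM, also a limit. The two differ by methoxy in place of fluoro on an aromatic carbon, and the step that the two limits leave unreadable from compound 1 to compound 2 cannot be sized because the limit of > 55000 nM in this assay, at which 1 of the 3 values shown sits, and the limit of > 54000 nM in this assay, at which 1 of the 3 values shown sits, are both limits. In this assay compound 3 gives > 62000 nM, again a limit, as the limit of > 62000 nM in this assay, at which 1 of the 3 values shown sits, shows. How the core of compound 3 differs from the core of compound 1 is not broken down here. Compound 4 `COc1ccc(C(=O)CSc2nc(Cc3c(F)cccc3F)c(C)c(=O)[nH]2)cc1` has not yet been measured; it differs from compound 3 by methoxy in place of fluoro on an aromatic carbon, at the same place as before, so this is the same change seen between compound 1 and compound 2. Since that change left both earlier compounds at limits, the expected step from compound 3 to compound 4 is a number no higher from compound 3 to compound 4 (the limit leaves the size open), and compound 4 is estimated to sit at 62000 nM, most likely again reported as a limit, between 35000 nM and 110000 nM.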

Compound 4, half-maximal cytotoxic concentration: > 60000 nM
Compound 4: no number, only a limit; the forecaster's own chance of this, stated with the estimate: 85%; the middle value does not contradict the limit.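

Compound 3 and compound 4 both stand at limits of this assay and not at numbers, and no step can be read between them. The compounds shown leave open where the true half-maximal cytotoxic concentrations lie, and whether going from 4-fluorophenyl to 4-methoxyphenyl changes them at all.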